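The source may report more compounds than this note shows. Statements on the series, on what has been measured and on what is new or still open speak of the compounds shown alone.

Compound 3 `CCCCCCCCc1ccc(OCC(=O)Cn2nnnc2-c2ccc(S(=O)(=O)N(C)C)cc2)cc1` gives 1400 nM in an assay on microsomes from brain for inhibition of Fatty-acid amide hydrolase 1 (Rattus norvegicus), read by fluorescence and HPLC, with a stated time of 60 min (a lower number here means a stronger inhibitor, a higher number a weaker inhibitor), the highest of the three numbers; compound 1 `CCCCCCCCc1ccc(OCC(=O)Cn2nnc(-c3ccc(S(=O)(=O)N(C)C)cc3)n2)cc1` gives 590 nM and compound 2 `CCCCCCCCc1ccc(OCC(=O)Cn2nnc(Cc3ccccc3)n2)cc1` gives 66 nM in this assay. Compound 4 `CCCCCCCCc1ccc(OCC(=O)Cn2nnnc2C(=O)OCC)cc1` is not yet measured in this assay; it differs from compound 3 by ethoxycarbonyl in place of 4-(dimethylsulfamoyl)phenyl on an aromatic carbon. Among the measured compounds shown here, the one measured step in which 4-(dimethylsulfamoyl)phenyl leaves is an 8.9-fold lower number from compound 1 to compound 2 (0.95 log units; beyond the scatter), although there benzyl enters and compound 1 and compound 2 carry the large group on the other carbon of the shared core. Given an 8.9-fold lower number from compound 1 to compound 2 (0.95 log units; beyond the scatter), a step toward a lower number, but smaller, is expected for compound 4, a 2.8-fold lower number from compound 3 to compound 4 (0.45 log units; beyond the scatter). Compound 4 is estimated at 500 nM, with a range from 120 nM to 2000 nM.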

Compound 4, half-maximal inhibitory concentration: 940 nM
Compound 4: middle estimate off by 1.9-fold (0.27 log units), on the low side, within the range that was stated.
By their numbers in this assay, from the lowest: compound 2; then compounds 1, 4 and 3 (each within the scatter of the next, the first and the last beyond it).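

On the aromatic carbon between two ring nitrogen atoms, ethoxycarbonyl in place of 4-(dimethylsulfamoyl)phenyl gives a 1.5-fold lower number from compound 3 to compound 4 (0.17 log units; within the scatter), so a substituent of 5 heavy atoms without a ring and one of 12 heavy atoms with a ring cannot be told apart here. Among the compounds shown here, the larger step seen on the other carbon of the shared core, an 8.9-fold lower number from compound 1 to compound 2 (0.95 log units; beyond the scatter), has no counterpart in this change, though benzyl entered there. Nothing at hand explains why these two groups read alike. Open, from the compounds shown here alone, is whether benzyl on this carbon would give a number near that of compound 2, and whether a carboxylic acid or a primary amide in place of ethoxycarbonyl would separate from compound 3.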